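The source may hold more compounds than are shown below. What is called first, only, known or untested is meant among the compounds shown, and "the series" means these compounds.

Compound 3 `COc1cc2c(cc1OC)C(CC(=O)N1CCCCC1)CC2` gives 32% in a functional assay on the whole organism (strain Wistar) for inhibition, with Rattus norvegicus as the target, read by paw edema, with stated times of 60 min and 4 h, at a dose of 100 mg/kg by the oral route; on this read-out higher numbers stand for more inhibition at the one dose given (going by the name of the read-out) and lower numbers for less inhibition. Among the three measured compounds it stands second highest: compound 1 `CCCNC(=O)CC1CCc2cc(OC)c(OC)cc21` gives 26.6%, a gap within the scatter, while compound 2 `COc1cc2c(cc1OC)C(CC(=O)NC1CCCC1)CC2` gives 45.3%. Compound 4 `COc1cc2c(cc1OC)C(CC(=O)N1CCOCC1)CC2` differs from compound 3 in one place: morpholin-4-yl in place of piperidin-1-yl on a carbonyl carbon. All three measured steps bear on this change, since each alters the group on the amide: a number 18.7 percentage points higher from compound 1 to compound 2 (beyond the scatter), a number 5.4 percentage points higher from compound 1 to compound 3 (within the scatter), and a number 13.3 percentage points lower from compound 2 to compound 3 (beyond the scatter). Replacing one ring of this kind with another has so far moved the read-out modestly at most, and nothing measured tests morpholin-4-yl directly. Compound 4 is therefore expected to show only a small change, a number 4 percentage points lower from compound 3 to compound 4 (within the scatter), estimated at 28% with a range from 12% to 44%.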

Compound 4, a percentage reported as inhibition, in the whole organism at one dose (the size of the read-out at that dose, not a potency): 13.3%
Compound 4: middle estimate off by 14.7 percentage points, on the high side; measured number inside the range.
By their numbers in this assay, from the lowest: compound 4; then compounds 1 and 3 (each within the scatter of the next); then compound 2.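

In this assay, going by these compounds alone, the ring on the carbonyl carbon proves more sensitive than the earlier compounds suggested: exchanging piperidin-1-yl for morpholin-4-yl, rings of equal size, gives a number 18.7 percentage points lower from compound 3 to compound 4 (beyond the scatter). The morpholin-4-yl amide also falls short of the other two amides, with a number 13.3 percentage points lower from compound 1 to compound 4 (beyond the scatter) and a number 32 percentage points lower from compound 2 to compound 4 (beyond the scatter), which makes compound 4 the lowest of the four.

No measurement shown explains this drop. Going by these compounds, whether another ring atom, such as the second nitrogen of a piperazin-1-yl group, would lower the number in the same way stays open.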